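Lengthening the ester chain: compound 3 to compound 4

This account rests on a few compounds, and the source may have more. Where it says the series, first, only, none or still open, it means among the compounds named here.

Measured in a functional assay on HeLa cells (Homo sapiens) for antiproliferative activity, read by MTT assay, with a stated time of 48 h; a lower number here means a stronger inhibitor of growth, a higher number a weaker inhibitor of growth:
- compound 1 `CCCOC(=O)N1N=C(c2ccccc2)CC1c1cc(OC)c(OC)c(OC)c1`: > 10000 nM (a limit, not a number)
- compound 2 `COC(=O)N1N=C(c2ccc(OC)cc2)CC1c1cc(OC)c(OC)c(OC)c1`: 2590 nM
- compound 3 `CCOC(=O)N1N=C(c2ccc(OC)cc2)CC1c1cc(OC)c(OC)c(OC)c1`: 8710 nM

Compound 3 holds the higher of the two true numbers. Compound 4 `CCCOC(=O)N1N=C(c2ccc(OC)cc2)CC1c1cc(OC)c(OC)c(OC)c1` changes ethoxy to propoxy, with methyl in place of hydrogen on a saturated chain carbon, two bonds along the chain from an oxygen next to a carbonyl group. Among the measured compounds shown here, the one measured step that bears on this is a 3.4-fold higher number from compound 2 to compound 3 (0.53 log units; beyond the scatter), where methyl entered on the chain carbon bound to that oxygen. A step of similar size towards a higher number is therefore expected in this assay, and a report at the limit of > 10000 nM in this assay, at which 1 of the 3 values shown sits, is likely. The expected change is a 2.3-fold higher number from compound 3 to compound 4 (0.36 log units; beyond the scatter). The estimate for compound 4 is 20000 nM, with an expected range of 7000 nM to 60000 nM.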

Compound 4, concentration for 50% growth inhibition: > 10000 nM
Compound 4 gave a limit, no number (the forecaster's own chance of this, stated with the estimate: 70%); the middle value does not contradict the limit.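

In this assay, on these data alone, ethoxy to propoxy gives an at least 1.1-fold higher number from compound 3 to compound 4 (0.05 log units; that floor lies within the scatter), a floor only, so the true size of this change stays unknown. The wider comparison gives an at least 3.8-fold higher number from compound 2 to compound 4 (0.58 log units; beyond the scatter), a floor beyond the scatter, so the weakening seen with the first methyl persists at propoxy. The step from compound 1 to compound 4 cannot be read, and the propoxy esters now sit at a limit, not a number: the limit of > 10000 nM in this assay, at which 2 of the 4 values shown sit.

Open, as far as these compounds go, is whether a longer chain such as butyl stays at this limit. Also open, from the compounds shown here alone, is whether an amine or a carboxylic acid at the chain end returns a measurable number.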